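Series notes: 4-chlorophenyl to phenethyl on the shared core

A few compounds are considered here, and "the series" means these few. Any claim that something is new, unique, unknown or untested is made for them only; others in the source may bear on it.

Measured compounds in an assay on CHO cells for displacement of a labelled ligand from adenosine receptor A3 (Homo sapiens), read by scintillation counting, tested at 1 uM; on this read-out higher numbers stand for more inhibition at the one concentration tested (going by the name of the read-out) and lower numbers for less inhibition:
compound 1 `Cc1ccc(Cc2nc(N)c3nn(-c4ccccc4)cc3n2)cc1` gives 39%
compound 2 `Nc1nc(Cc2cccc(Cl)c2)nc2cn(-c3ccccc3)nc12` gives 42%
compound 3 `Nc1nc(Cc2ccc(Cl)cc2)nc2cn(-c3ccccc3)nc12` gives 11%

Compound 3 stands lowest of the three numbers in this assay. Compound 4 `Nc1nc(CCCc2ccccc2)nc2cn(-c3ccccc3)nc12` has not been measured; the change is phenethyl in place of 4-chlorophenyl on a saturated chain carbon bound to an aromatic carbon. Among the measured compounds shown here, two measured steps touch the same place: a number 28 percentage points lower from compound 1 to compound 3 (beyond the scatter) and a number 31 percentage points lower from compound 2 to compound 3 (beyond the scatter), both ending at compound 3. The step of a number 3 percentage points higher from compound 1 to compound 2 (within the scatter) shows that the two other groups at this place read alike. For the measured compounds named here, no measured step covers a longer chain, so the size of the step is uncertain; removing the 4-chlorophenyl is expected to recover part of the loss, giving an expected step of a number 19 percentage points higher from compound 3 to compound 4 (beyond the scatter). Compound 4 is therefore estimated at 30%, in a range from 10% to 50%.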

Compound 4, a percentage reported as inhibition, at one concentration (the size of the read-out at that concentration, not a potency): 12%
For compound 4 the middle estimate is 18 percentage points above the measured one, within the range that was stated.
By their numbers in this assay, from the lowest: compounds 3 and 4 (each within the scatter of the next); then compounds 1 and 2 (each within the scatter of the next).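

In this assay, phenethyl in place of 4-chlorophenyl gives a number 1 percentage points higher from compound 3 to compound 4 (within the scatter), so the low reading is not tied to the chlorine of compound 3. Phenethyl in place of 3-chlorophenyl gives a number 30 percentage points lower from compound 2 to compound 4 (beyond the scatter), and phenethyl in place of 4-methylphenyl gives a number 27 percentage points lower from compound 1 to compound 4 (beyond the scatter), so two different groups at this place now share the low reading. From the compounds shown here alone, whether an amine or a carboxylic acid on a saturated chain carbon bound to an aromatic carbon would read with compound 3 and compound 4 or with compound 1 and compound 2 stays open. No available data explain these readings.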